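This account rests on a few compounds, and the source may have more. Where it says the series, first, only, none or still open, it means among the compounds named here.

Measured in a functional assay on the whole organism (strain Kunming) with Mus musculus as the target, with a stated time of 0.5 h; a lower number here means that less compound is needed, a higher number that more compound is needed for the effect:
- Compound 1 `COc1cc(OC)c(OC)cc1/C=C/COC(=O)/C=C/c1ccc(OC)c(OC)c1`: 418 umol/kg
- Compound 2 `COc1cc(OC)c(OC)cc1/C=C/COC(=O)/C=C/c1ccc(Br)cc1`: 446 umol/kg
- Compound 3 `COc1cc(OC)c(OC)cc1/C=C/COC(=O)/C=C/c1ccccc1C(F)(F)F`: > 473 umol/kg

The entry for compound 3 is a limit of the assay and not a number. Going by the values given here, compound 1 has only one numerical neighbour, and the two cannot be ranked: the measured difference is a 1.1-fold higher number from compound 1 to compound 2 (0.03 log units; within the scatter). The position of compound 1 is therefore level with compound 2, not ahead of it.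

Compound 4 `COc1cc(OC)c(OC)cc1/C=C/COC(=O)/C=C/c1ccc(OC)c(OC)c1OC` keeps the core of compound 1 and makes one small alteration, methoxy in place of hydrogen on an aromatic carbon.

The closest guidance comes from the two measured steps that replace the 3,4-dimethoxyphenyl group, the part of compound 1 altered in compound 4. One is the step already given. The other is an at least 1.1-fold higher number from compound 1 to compound 3 (0.05 log units; that floor lies within the scatter). Even these larger replacements produced no shift that can be told from the scatter, although the second rests on a limit. A single added methoxy is thus expected to cause no step beyond the scatter, and no direction can be favoured. The expected step is a 1.0-fold lower number from compound 1 to compound 4 (0.02 log units; within the scatter). The estimate for compound 4 is 400 umol/kg, with an expected range from 200 umol/kg to 650 umol/kg.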

Compound 4, dose for half-maximal effect: 456 umol/kg
Compound 4: the middle estimate sits 1.1-fold (0.06 log units) below what was measured, and the stated range covers the measured number.
By their numbers in this assay, from the lowest: compounds 1, 2 and 4 (each within the scatter of the next). At a limit, above all of these: compound 3.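

In this assay, adding one methoxy to the 3,4-dimethoxyphenyl group of compound 1 gives a 1.1-fold higher number from compound 1 to compound 4 (0.04 log units; within the scatter). The earlier steps shown here exchanged the whole aromatic group, whereas this one changes a single aromatic carbon, ortho to a large group and ortho to a methoxy group, and it shows that a methoxy can take the place of hydrogen there with no step that can be told from the scatter. Compound 3 remains a limit of the assay and not a number, so its standing against compound 4 cannot be read: the limit of > 473 umol/kg in this assay, at which 1 of the 4 values shown sits.

On these data alone, only hydrogen and methoxy appear at this position, so it remains open whether an amine or a carboxylic acid there would bring a step beyond the scatter in either direction. As far as these compounds go, it is equally open whether a longer chain on the oxygen of the new methoxy would do so, or whether this position matters at all for the dose needed in this whole-animal test.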